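Methoxy added to compound 3: expected small step

The source may hold more compounds than are shown below. What is called first, only, known or untested is meant among the compounds shown, and "the series" means these compounds.

In a functional assay on CNE-2 cells (Homo sapiens) for antiproliferative activity, read by sulforhodamine B assay, with a stated time of 48 h (on this read-out lower numbers stand for stronger inhibition and higher numbers for weaker inhibition), compound 3 (`COc1ccc(/C=C/C(=O)c2ccccc2-c2ccc(F)nc2)cc1`) gives 160 nM. Compound 2 (`COc1ccc(/C=C/C(=O)c2ccccc2-c2ccc(F)cc2)cc1OC`) gives 81 nM, and these two numbers lie within the scatter of each other. Compound 1 (`COc1ccc(/C=C/C(=O)c2ccccc2-c2ccc(OC)c(OC)c2)cc1OC`) gives 2500 nM, a much higher number than either.

Compound 4 (`COc1ccc(/C=C/C(=O)c2ccccc2-c2ccc(F)nc2)cc1OC`) arises from compound 3 through a single change: methoxy in place of hydrogen on an aromatic carbon. This is methoxy in place of hydrogen on an aromatic carbon, ortho to a methoxy group and meta to a large group.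

Among the compounds with values here, only one measured step is available, a 31-fold lower number from compound 1 to compound 2 (1.49 log units; beyond the scatter). It is large and beyond the scatter, but it is an exchange of 3,4-dimethoxyphenyl for 4-fluorophenyl at a different place in the molecule. Within the data shown here, its size therefore does not carry over, and no measured step tests the new methoxy directly. The closest guide is compound 2 at 81 nM, which already carries a methoxy at this place but differs from compound 3 in more than one place.

The expectation is therefore a small shift towards stronger inhibition, an estimated 1.5-fold lower number from compound 3 to compound 4 (0.16 log units; within the scatter), which stays within the scatter. Compound 4 is expected at 110 nM, with an estimated range of 45 nM to 280 nM.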

Compound 4, half-maximal inhibitory concentration: 1600 nM
For compound 4 the middle estimate is 15-fold (1.16 log units) below the measured one; measured number outside the range, above it.
By their numbers in this assay, from the lowest: compounds 2 and 3 (each within the scatter of the next); then compounds 4 and 1 (each within the scatter of the next).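

In this assay, methoxy in place of hydrogen on an aromatic carbon, ortho to a methoxy group and meta to a large group, is not a neutral change on the 6-fluoropyridin-3-yl series: a 10-fold higher number from compound 3 to compound 4 (1.00 log units; beyond the scatter). With that methoxy present, the exchanged aryl group also separates the compounds, since 6-fluoropyridin-3-yl in place of 4-fluorophenyl gives a 20-fold higher number from compound 2 to compound 4 (1.30 log units; beyond the scatter), whereas 6-fluoropyridin-3-yl in place of 3,4-dimethoxyphenyl gives a 1.6-fold lower number from compound 1 to compound 4 (0.19 log units; within the scatter), which leaves compound 1 and compound 4 without an order and compound 2 apart from both. No measurement shown here accounts for either the methoxy step or the difference between the aryl groups.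

Still open is whether the added methoxy gives a step of similar size when 4-fluorophenyl stands in place of 6-fluoropyridin-3-yl, as the compounds shown contain no pair that tests this. Also open, going by these compounds, is how this assay would read with a hydroxy group, an amine or a longer chain such as ethoxy in place of the added methoxy.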